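Side-Chain Swap and Expected Lipophilicity

A few compounds are considered here, and "the series" means these few. Any claim that something is new, unique, unknown or untested is made for them only; others in the source may bear on it.

Compound 1 `CC(C)C(NC(=O)c1ccc(C#Cc2ccccc2)cc1)C(=O)NO` was measured in a physicochemical assay for lipophilicity; a higher number here means a more lipophilic compound, a lower number a more polar compound. In this assay compound 1 gives > 3, which is a limit of the assay rather than a number. Compound 2 `O=C(NC1(C(=O)NO)CCN(Cc2ccccc2)CC1)c1ccc(C#Cc2ccccc2)cc1` was measured too. In this assay compound 2 gives > 3, again only a limit. Both results share one feature: the limit of > 3 in this assay, at which 2 of the 2 values shown sit. Compound 3 `CSC[C@H](NC(=O)c1ccc(C#Cc2ccccc2)cc1)C(=O)NO` differs from compound 1 at one place: a group of 8 heavy atoms (4 carbon, 1 nitrogen, 2 oxygen, 1 sulfur; no ring) in place of a group of 8 heavy atoms (5 carbon, 1 nitrogen, 2 oxygen; no ring), on an amide-type nitrogen. Within the data shown here, with no measured step to guide this change, the expected step is a step that the limit leaves unreadable from compound 1 to compound 3, none beyond the scatter. Compound 3 is therefore expected to give about 3.2, between 2.7 and 3.8.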

Compound 3, distribution coefficient: 3
Compound 3: middle estimate off by 0.20 log units, on the high side, within the range that was stated.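

In this assay, among these compounds, compound 3 gives 3, the only value shown that is a number and not a limit. On an amide-type nitrogen, the sulfur-bearing group in place of 1-(hydroxycarbamoyl)-2-methylpropyl gives a number no higher from compound 1 to compound 3 (the limit leaves the size open). The change can therefore be read for direction only, and its size stays open because of a feature shared by the results: the limit of > 3 in this assay, at which 2 of the 3 values shown sit.

Going by these compounds, what a carboxylic acid or a longer sulfur-bearing chain at this place would give in this assay remains open.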